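Swapping Phenyl for 4-Fluorophenoxy on a Shared Core

A few compounds are considered here, and "the series" means these few. Any claim that something is new, unique, unknown or untested is made for them only; others in the source may bear on it.

Measured so far:
compound 1 `COc1ccc(Oc2ccc3c(NCCCNCc4cc(F)ccc4OC)ccnc3c2)cc1`: 9.28
compound 2 `c1ccc(-c2ccc3c(NCCCNCc4ccco4)ccnc3c2)cc1`: 9.47
compound 3 `COc1cccc(CNCCCNc2ccnc3cc(-c4ccc(C(F)(F)F)cc4)ccc23)c1O`: 9.47

All three compounds share one core and were measured in a physicochemical assay for acid dissociation. Compound 2 gives 9.47, level with compound 3 at the digits shown, the two together the highest of the three numbers; compound 1 lies lower by an amount within the scatter, so no firm order exists among them. Compound 4, `Fc1ccc(Oc2ccc3c(NCCCNCc4ccco4)ccnc3c2)cc1`, is not yet measured. It differs from compound 2 as follows: 4-fluorophenoxy in place of phenyl on an aromatic carbon. Compound 1 carries a different substituent at that same kind of position and still gives 9.28, within the scatter of compound 2. No step beyond the scatter is therefore expected in this assay. Compound 4 is estimated at 9.4, range 9.1 to 9.7. This corresponds to an expected change of a number 0.07 log units lower from compound 2 to compound 4 (within the scatter).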

Compound 4, acid dissociation constant: 9.28
Beside the measured number, compound 4's estimate is 0.12 log units above it, within the range that was stated.
By their numbers in this assay, from the lowest: compounds 1, 4, 2 and 3 (each within the scatter of the next).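

In this assay, among these compounds, this pair gives the first direct reading of a single change at this position: 4-fluorophenoxy in place of phenyl gives a number 0.19 log units lower from compound 2 to compound 4 (within the scatter). Adding an oxygen and a fluorine to the group at this aromatic carbon therefore produces no step that can be told from repeat-measurement noise. No measured information here bears on why the number stays within that scatter. Still open, on these data alone, is whether an amine or a carboxylic acid on this same aromatic carbon would shift the number beyond the scatter.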